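The compounds below may be only part of what the source reports. "The series", "measured", "known", "first", "only" and "open" are said of these compounds alone.

Three compounds share a chlorobenzyl group on a fused two-ring core and were run in a functional assay on HT-29 cells (Homo sapiens) for cytotoxicity, read by sulforhodamine B assay, with a stated time of 48 h; on this read-out higher numbers stand for weaker inhibition of growth and lower numbers for stronger inhibition of growth. Compound 1 `ClCc1cccc(Cn2cnc3ncnc(Cl)c32)c1` gives 2880 nM. Compound 2 `ClCc1cccc(Cn2cnc3c(Cl)ncnc32)c1` gives 3230 nM, and compound 3 `ClCc1cccc(Cn2cnc3c(Cl)nc(Cl)nc32)c1` gives 2390 nM. The difference between the cores of compound 1 and compound 2 is not broken down here. Compound 3 arises from compound 2 by chloro in place of hydrogen on an aromatic carbon, and that step produced a 1.4-fold lower number from compound 2 to compound 3 (0.13 log units; within the scatter).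

Compound 4 `ClCc1cccc(Cn2cnc3nc(Cl)nc(Cl)c32)c1` is not yet measured. It differs from compound 1 by chloro in place of hydrogen on an aromatic carbon, the same change that was made from compound 2 to compound 3. Because the step of a 1.4-fold lower number from compound 2 to compound 3 (0.13 log units; within the scatter) stayed within the scatter, compound 4 is expected to stay close to compound 1, with an estimated step of a 1.3-fold lower number from compound 1 to compound 4 (0.12 log units; within the scatter). On that basis compound 4 is expected to give about 2200 nM in this assay, with a plausible range from 1100 nM to 4500 nM.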

Compound 4, concentration for 50% growth inhibition: 340 nM
Compound 4: middle estimate off by 6.5-fold (0.81 log units), on the high side, outside the stated range (below it).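

In this assay, chloro in place of hydrogen on an aromatic carbon produced an 8.5-fold lower number from compound 1 to compound 4 (0.93 log units; beyond the scatter), a step beyond the scatter. The size of this step therefore did not carry over from one core to the other, since the same change had stayed within the scatter on the other core: the same change on two cores in this assay, a 1.4-fold lower number (0.13 log units; within the scatter) from compound 2 to compound 3 and an 8.5-fold lower number (0.93 log units; beyond the scatter) from compound 1 to compound 4, 6.3-fold (0.80 log units) apart, beyond the scatter of two such steps. For the compounds shown here, with only two pairs, this shows that the outcome of the change depends on the core, but it does not show why the two cores differ, nor which of the two steps would be the better guide on a further core.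

The compounds shown leave open whether an amine, a methoxy group or a methyl group in place of the chloro between two ring nitrogen atoms would give a comparable step on the core of compound 1. They also leave open whether the chloromethyl group on the benzyl ring is needed for the step, as all four compounds carry it.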